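2,6-Dichlorophenyl gives way to 4-methylphenyl

This account rests on a few compounds, and the source may have more. Where it says the series, first, only, none or still open, it means among the compounds named here.

Compound 2 `Cc1oc(-c2c(Cl)cccc2Cl)nc1CN1CCC(C(=O)NCCCN2C[C@H](C)C[C@H](C)C2)CC1` stands at > 77 ug/mL in a physicochemical assay for solubility, in phosphate buffer, measured as kinetic solubility, at pH 7.4 (a lower number here means a less soluble compound, a higher number a more soluble compound), and this reading is a limit of the assay, not a number. Compound 1 `Cc1ccccc1-c1nc(CN2CCC(C(=O)NCCCN3CCC(C(C)C)CC3)CC2)c(C)o1` gives > 71 ug/mL as a limit too. Compound 3 `Cc1cccc(Cl)c1-c1nc(CN2CCC(C(=O)NCCCN3CCC(C(C)C)CC3)CC2)c(C)o1` gives > 76 ug/mL as a limit as well. No measured number therefore places compound 2 against the other two, and no order among the three can be read.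

Compound 4 `Cc1ccc(-c2nc(CN3CCC(C(=O)NCCCN4C[C@H](C)C[C@H](C)C4)CC3)c(C)o2)cc1` has not yet been measured. It differs from compound 2 in one place 4-methylphenyl in place of 2,6-dichlorophenyl on an aromatic carbon and the change is that 4-methylphenyl takes the place of 2,6-dichlorophenyl on an aromatic carbon. Neither group carries a net charge.

Going by the values given here, the one measured step that bears on this change is a step that the two limits leave unreadable from compound 1 to compound 3 with chloro in place of hydrogen on an aromatic carbon, and with no size to carry over from it, no step beyond the scatter is expected in this assay in either direction. The estimated step is an at least 1.0-fold lower number from compound 2 to compound 4 (0.01 log units; that floor lies within the scatter) and it is expected to stay within the scatter. For compound 4 the estimate is 75 ug/mL with an expected range from 45 ug/mL to 90 ug/mL and the reading may again turn out to be only a limit.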

Compound 4, solubility: > 69 ug/mL
Compound 4: a limit, no number; the forecaster's own chance of this, stated with the estimate: 75%; the middle value does not contradict the limit.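

In this assay compound 4 gives > 69 ug/mL, which is a limit of the assay and not a number. Compound 2 also has only a limit, and the step between compound 2 and compound 4 cannot be read. The compounds shown leave open where the true readings lie, and whether 4-methylphenyl in place of 2,6-dichlorophenyl changes the reading in this assay at all.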